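Ring-nitrogen aryl swap from compound 1 to compound 4

A few compounds are considered here, and "the series" means these few. Any claim that something is new, unique, unknown or untested is made for them only; others in the source may bear on it.

Three compounds share the thiazolidinone-bearing core of compound 1 `COc1ccc(OC)c(N2C(=O)CSC2c2cccc(C(=O)NCCCCc3ccccc3)c2)c1`. In a functional assay on HOS cells (Homo sapiens) for inhibition, read by CCK-8 assay, with a stated time of 72 h, tested at 1 uM (a higher number here means more inhibition at the concentration tested (going by the name of the read-out), a lower number less inhibition), compound 1 gives 5%, the second highest of the three numbers. Compound 2 `COc1ccccc1N1C(=O)CSC1C(=O)NCCCCc1ccccc1` gives 0% in this assay, a value within the scatter of that of compound 1, so the two are not distinguished. Among the compounds with values here, compound 3 `O=C(NCCCCc1ccccc1)c1cccc(C2SCC(=O)N2c2ccccc2)c1` gives 55%, and the step of a number 50 percentage points higher from compound 1 to compound 3 (beyond the scatter) is the only measured change at the ring nitrogen.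

Compound 4 `CC(F)(F)c1cccc(N2C(=O)CSC2c2cccc(C(=O)NCCCCc3ccccc3)c2)c1` is not yet measured. It differs from compound 1 by a group of 10 heavy atoms (8 carbon, 2 fluorine; one six-membered aromatic ring of carbon only) in place of a group of 10 heavy atoms (8 carbon, 2 oxygen; one six-membered aromatic ring of carbon only), on an amide-type nitrogen in a ring. The bearing step is that from compound 1 to compound 3, where removing both methoxy groups raised inhibition by a large amount. Compound 4 also loses the 2,5-dimethoxyphenyl, but what enters is not the plain phenyl of compound 3, so a smaller gain than a number 50 percentage points higher from compound 1 to compound 3 (beyond the scatter) is expected, with a wide range. The expected step is a number 25 percentage points higher from compound 1 to compound 4 (beyond the scatter), an increase beyond the scatter. For compound 4 the estimate in this assay is 30%, between 5% and 60%.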

Compound 4, a percentage reported as inhibition, at one concentration (the size of the read-out at that concentration, not a potency): 23%
Compound 4: the middle estimate sits 7 percentage points above what was measured; measured number inside the range.
By their numbers in this assay, from the lowest: compounds 2 and 1 (each within the scatter of the next); then compound 4; then compound 3.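

In this assay a substituted phenyl on the amide-type nitrogen in a ring keeps part of the gain seen with the plain phenyl: the change gives a number 18 percentage points higher from compound 1 to compound 4 (beyond the scatter) and shows that the low reading of the 2,5-dimethoxyphenyl compound is not shared by every substituted phenyl here. Substitution on the phenyl is still not neutral, as 1,1-difluoroethyl in place of hydrogen on an aromatic carbon gives a number 32 percentage points lower from compound 3 to compound 4 (beyond the scatter) in the same assay. Nothing on hand gives a reason for either step.

Open, from the compounds shown here alone, is whether the loss follows 1,1-difluoroethyl specifically or any group on this phenyl, which a single fluorine, a methyl or a trifluoromethyl would help separate. Also open, going by these compounds, is how one methoxy group, an amine or a carboxylic acid on this phenyl would read.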